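Chloro gives way to 1H-pyrazol-1-yl in compound 3

The compounds below may be only part of what the source reports. "The series", "measured", "known", "first", "only" and "open" are said of these compounds alone.

In a functional assay on SW-620 cells (Homo sapiens) for cytotoxicity, read by MTT assay, with stated times of 4 h and 72 h, tested at 2 uM (on this read-out higher numbers stand for weaker inhibition and lower numbers for stronger inhibition), three compounds differing only in one substituted phenyl group have been measured. Compound 1 `COc1ccc(/C=C/C(=O)c2ccc(Nc3cc(C)nc4nc(SCc5nc6ccccc6[nH]5)nn34)cc2)cc1F` gives 140 nM, compound 2 `Cc1cc(Nc2ccc(C(=O)/C=C/c3ccc(F)cc3)cc2)n2nc(SCc3nc4ccccc4[nH]3)nc2n1` gives 85 nM, and compound 3 `Cc1cc(Nc2ccc(C(=O)/C=C/c3ccc(Cl)cc3)cc2)n2nc(SCc3nc4ccccc4[nH]3)nc2n1` gives 230 nM. The last of these stands at a 1.6-fold higher number from compound 1 to compound 3 (0.22 log units; within the scatter), so it cannot be separated from its nearest neighbour, while the other gap is a 2.7-fold higher number from compound 2 to compound 3 (0.43 log units; beyond the scatter).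

The next structure is compound 4 `Cc1cc(Nc2ccc(C(=O)/C=C/c3ccc(-n4cccn4)cc3)cc2)n2nc(SCc3nc4ccccc4[nH]3)nc2n1`. The change is 1H-pyrazol-1-yl in place of chloro on an aromatic carbon, para to a large group. The measured steps that bear on it are those at this same phenyl group. One is a 1.6-fold lower number from compound 1 to compound 2 (0.22 log units; within the scatter), and the largest, the swap of chloro for fluoro, is the modest one already given. Among the measured compounds shown here, none of the measured compounds carries a ring at this place, so the data offer no direction for the change and only a rough guide to its size. No shift beyond the scatter is therefore expected, and the estimate is a 1.2-fold lower number from compound 3 to compound 4 (0.08 log units; within the scatter). For compound 4 the estimated value is 190 nM, with an expected range of 60 nM to 600 nM.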

Compound 4, half-maximal inhibitory concentration: 340 nM
For compound 4 the middle estimate is 1.8-fold (0.25 log units) below the measured one, within the range that was stated.
By their numbers in this assay, from the lowest: compounds 2, 1, 3 and 4 (each within the scatter of the next, the first and the last beyond it).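

In this assay, this position now carries a ring, and the step from chloro to 1H-pyrazol-1-yl, with five heavy atoms and two hydrogen-bond acceptors entering where one chlorine leaves, is a 1.5-fold higher number from compound 3 to compound 4 (0.17 log units; within the scatter) and so leaves compound 3 and compound 4 inseparable. Compound 4 does stand apart from the other two, with a 4.0-fold higher number from compound 2 to compound 4 (0.60 log units; beyond the scatter) when 1H-pyrazol-1-yl takes the place of fluoro, and with a 2.4-fold higher number from compound 1 to compound 4 (0.39 log units; beyond the scatter) when 4-(1H-pyrazol-1-yl)phenyl takes the place of 3-fluoro-4-methoxyphenyl, both steps being modest. No measurement at hand explains any of these steps.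

On these data alone, what remains open is how far this position tolerates groups of other kinds, such as an amine, a carboxylic acid, a morpholine ring or a longer chain. As far as these compounds go, it is also open whether the two nitrogen atoms of the 1H-pyrazol-1-yl group count for anything in this read-out, a question that a plain phenyl group at this place would help to settle.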